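Swapping one ring substituent in a pyrazole urea series

The compounds below may be only part of what the source reports. "The series", "measured", "known", "first", "only" and "open" are said of these compounds alone.

Measured compounds:
Compound 1 `O=C(Nc1cccc(-n2cc(-c3ccncc3)c(-c3cc(O)cc(Cl)c3)n2)c1)Nc1ccc(Cl)c(Cl)c1`: 110%
Compound 2 `COc1cc(Cl)cc(-c2nn(-c3cccc(NC(=O)Nc4ccc(Cl)c(C(F)(F)F)c4)c3)cc2-c2ccncc2)c1`: 100%

Both compounds were tested in a functional assay on SK-OV-3 cells (Homo sapiens) for inhibition, read by sulforhodamine B assay, with a stated time of 48 h, tested at 1 uM; a higher number here means a weaker effect of the compound at the concentration tested, a lower number a stronger effect. Compound 2 gives 100%, the lowest of the two numbers, and compound 1 gives 110%, a number only slightly higher and within the usual scatter, so neither can be called the stronger. Both values sit near the level that means essentially no inhibition at this concentration.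

Compound 3 `COc1cc(Cl)cc(-c2nn(-c3cccc(NC(=O)Nc4ccc(Cl)c(Cl)c4)c3)cc2-c2ccncc2)c1` has not been measured. It differs from compound 2 in a single place: chloro in place of trifluoromethyl on an aromatic carbon. Nothing in the two measured compounds shows such a swap changing the read-out, and both sit near the no-effect level. The expected step from compound 2 to compound 3 in this assay is therefore a number 4 percentage points higher from compound 2 to compound 3 (within the scatter), essentially none beyond the scatter. Compound 3 is estimated to give 104%, with a likely range from 85% to 120%.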

Compound 3, a percentage reported as activity, at one concentration (the size of the read-out at that concentration, not a potency): 100%
Compound 3: the middle estimate sits 4 percentage points above what was measured; the range from low to high includes it.
By their numbers in this assay, from the lowest: compounds 2, 3 and 1 (each within the scatter of the next).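

In this assay, chloro in place of trifluoromethyl on this aromatic carbon gives no change at the digits printed from compound 2 to compound 3 (within the scatter), so the 3,4-dichlorophenyl and 4-chloro-3-(trifluoromethyl)phenyl groups cannot be told apart here. Compound 3 also provides a second comparison in a single place: methyl in place of hydrogen on the oxygen gives a number 10 percentage points lower from compound 1 to compound 3 (within the scatter). Neither change moves the read-out beyond the scatter, and all three compounds stay near the no-effect level, so these swaps bring no detectable inhibition at this one concentration.

Nothing available explains this lack of change. It remains open whether an amine or a carboxylic acid on this aromatic carbon, or a longer chain on the oxygen, would lower the number, and whether any of these compounds acts at a higher concentration.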